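The source may report more compounds than this note shows. Statements on the series, on what has been measured and on what is new or still open speak of the compounds shown alone.

Measured compounds:
- compound 1, `CC(C)=CCc1c(OCC(=O)N2CCOCC2)ccc2ccc(=O)oc12`
- compound 2, `CC(C)=CCc1c(OCC(=O)N2CCCC2)ccc2ccc(=O)oc12`
- compound 3, `CC(C)=CCc1c(OCC(=O)N2CCN(C(=O)OC(C)(C)C)CC2)ccc2ccc(=O)oc12`

In a functional assay on SH-SY5Y cells (Homo sapiens) for cytotoxicity, read by MTT assay (on this read-out lower numbers stand for an effect already at smaller amounts and higher numbers for an effect only at larger amounts of compound), compound 1 gives only a limit, > 100000 nM. In this assay compound 2 gives 15300 nM. In this assay compound 3 gives 3270 nM, the lowest number of the two numbers present; the nearest is compound 2, a step that lies beyond the scatter. Compound 1 sits at a limit rather than a number (the limit of > 100000 nM in this assay, at which 1 of the 3 values shown sits).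

Among the measured compounds shown here, the only measured single step, an at least 6.5-fold lower number from compound 1 to compound 2 (0.81 log units; beyond the scatter), exchanges the ring on the amide carbonyl and does not touch a substituent on a ring amine nitrogen, so it does not speak directly to the change at hand.

Compound 4, `CCN1CCN(C(=O)COc2ccc3ccc(=O)oc3c2CC=C(C)C)CC1`, differs from compound 3 by ethyl in place of tert-butoxycarbonyl on an amine nitrogen in a ring. For the measured compounds named here, no measured pair of the shared core carries this kind of change on the amine nitrogen in the ring, so the direction of the step is not anchored by anything measured. The step of a 1.8-fold higher number from compound 3 to compound 4 (0.26 log units; within the scatter) is therefore expected to stay close to compound 3, and is given a wide range either way. Compound 4 is estimated at 6000 nM in this assay, with a range from 1500 nM to 40000 nM.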

Compound 4, half-maximal effective concentration: 12500 nM
The estimate for compound 4 lay 2.1-fold (0.32 log units) below the measured number; the range from low to high includes it.
By their numbers in this assay, from the lowest: compound 3; then compounds 4 and 2 (each within the scatter of the next). At a limit, above all of these: compound 1.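

In this assay, a change on the amine nitrogen in the ring now has a measured size: ethyl in place of tert-butoxycarbonyl gives a 3.8-fold higher number from compound 3 to compound 4 (0.58 log units; beyond the scatter), so this position is not silent, and compound 3 keeps the lowest number of the series. With ethyl on that nitrogen, 4-ethylpiperazin-1-yl in place of pyrrolidin-1-yl on the carbonyl carbon gives a 1.2-fold lower number from compound 2 to compound 4 (0.09 log units; within the scatter), so these two amides cannot be ordered. 4-ethylpiperazin-1-yl in place of morpholin-4-yl gives an at least 8.0-fold lower number from compound 1 to compound 4 (0.90 log units; beyond the scatter), which is only a bound, as compound 1 stands at a limit: the limit of > 100000 nM in this assay, at which 1 of the 4 values shown sits.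

Ethyl and tert-butoxycarbonyl differ both in the carbonyl and in the number of heavy atoms, so it stays open which of the two goes with the step; an acetyl group, a longer alkyl chain such as n-butyl, or the free ring amine on the same nitrogen would begin to separate them. On these data alone, whether the change keeps its size on any other core also stays open.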